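The source may hold more compounds than are shown below. What is called first, only, known or untested is meant among the compounds shown, and "the series" means these compounds.

Measured compounds:
Compound 1 `COc1cccc(CNCCCNc2ccnc3cc(C4CCCCC4)ccc23)c1O`: 23 10^-6 cm/s
Compound 2 `COc1ccc(F)cc1CNCCCNc1ccnc2cc(C3CCCCC3)ccc12`: 23 10^-6 cm/s
Compound 3 `COc1ccc(-c2ccc3c(NCCCNCc4cc(F)ccc4OC)ccnc3c2)cc1`: 237 10^-6 cm/s

All three were measured in an ADME assay for permeability, using PAMPA, with a stated time of 30 min, at pH 7.4; on this read-out lower numbers stand for lower permeability and higher numbers for higher permeability. Compound 1 stands level with compound 2, the step of no change at the digits printed from compound 1 to compound 2 (within the scatter) showing that the change on the saturated chain carbon left the read-out unmoved; together the two hold the lowest numbers of the three. Compound 3 sits far above them, the step of a 10-fold higher number from compound 2 to compound 3 (1.01 log units; beyond the scatter) being large and well beyond the scatter.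

Compound 4 `COc1ccccc1Oc1ccc2c(NCCCNCc3cccc(OC)c3O)ccnc2c1` has not yet been measured in this assay. It differs from compound 1 at a single place: 2-methoxyphenoxy in place of cyclohexyl on an aromatic carbon. The step that bears most on this change is a 10-fold higher number from compound 2 to compound 3 (1.01 log units; beyond the scatter), where an aromatic group likewise entered on an aromatic carbon of the shared core in place of cyclohexyl and the number rose sharply. The step of no change at the digits printed from compound 1 to compound 2 (within the scatter) shows that compound 1 and compound 2 behave alike, so that comparison should carry over to compound 1. Since compound 4 carries 2-methoxyphenoxy rather than 4-methoxyphenyl, the size is less certain, but a rise beyond the scatter is expected, a 6.5-fold higher number from compound 1 to compound 4 (0.81 log units; beyond the scatter). Compound 4 is therefore estimated to give 150 10^-6 cm/s, with a range from 50 10^-6 cm/s to 400 10^-6 cm/s.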

Compound 4, apparent permeability: 317 10^-6 cm/s
Beside the measured number, compound 4's estimate is 2.1-fold (0.32 log units) below it; low and high end bracket the measured number.
By their numbers in this assay, from the lowest: compounds 1 and 2 (each within the scatter of the next); then compounds 3 and 4 (each within the scatter of the next).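

Replacing cyclohexyl with 2-methoxyphenoxy on this aromatic carbon gives, in this assay, a 14-fold higher number from compound 1 to compound 4 (1.14 log units; beyond the scatter), so the large rise at this position is now read directly on compound 1 rather than carried over from its fluorinated partner. Set beside a 10-fold higher number from compound 2 to compound 3 (1.01 log units; beyond the scatter), this shows a large rise with two different aromatic groups entering in place of cyclohexyl, and on two different groups at the far end of the chain, so neither rise depends on one particular combination of the two. The step alone cannot say what drives the rise, as the entering group differs from cyclohexyl in its aromatic ring, its size and its two hydrogen-bond acceptors, and no measurement shown here bears on the cause.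

From the compounds shown here alone, it remains open whether the aromatic ring or the oxygen atoms matter more, a question that a plain phenyl group or a cyclohexyloxy group at the same carbon would address. Going by these compounds, it is also open how far the rise would hold with a charged or strongly polar group there, such as a dimethylamino group or a carboxylic acid.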